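Swapping methoxy for methylamino on the piperidine arm

The compounds below may be only part of what the source reports. "The series", "measured", "known", "first", "only" and "open" are said of these compounds alone.

Measured compounds:
compound 1 `CCCCCOC(=O)N1CCN(C(=O)[C@H](CCC(=O)O)NC(=O)c2cc(N3CCC(C(=O)NCC)CC3)nc(-c3ccccc3)n2)CC1` with 0.005 h
compound 2 `CCCCCOC(=O)N1CCN(C(=O)[C@H](CCC(=O)O)NC(=O)c2cc(N3CCC(COC)CC3)nc(-c3ccccc3)n2)CC1` with 0.015 h

In an in vivo ADME assay on the whole organism (strain Sprague-Dawley) for metabolic stability, with Rattus norvegicus as the target (on this read-out lower numbers stand for a shorter-lived compound and higher numbers for a longer-lived compound), compound 2 stands as the higher of the two numbers; the nearest is compound 1, and the step of a 3.0-fold higher number from compound 1 to compound 2 (0.48 log units; beyond the scatter) lies beyond the scatter.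

Compound 3 `CCCCCOC(=O)N1CCN(C(=O)[C@H](CCC(=O)O)NC(=O)c2cc(N3CCC(CNC)CC3)nc(-c3ccccc3)n2)CC1` carries one change: methylamino in place of methoxy on a saturated chain carbon bound to a saturated ring carbon. For the measured compounds named here, no measured step tests this exact change. Going by the values given here, the only step at this part of the molecule is a 3.0-fold higher number from compound 1 to compound 2 (0.48 log units; beyond the scatter), a modest one, so a step of comparable size or none beyond the scatter is expected in this assay, in either direction.

For compound 3 an estimated 0.012 h is expected, within 0.004 h to 0.04 h, meaning a step of a 1.3-fold lower number from compound 2 to compound 3 (0.10 log units; within the scatter).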

Compound 3, half-life: 0.0117 h
Compound 3: the middle estimate sits 1.0-fold (0.01 log units) above what was measured, and the stated range covers the measured number.
By their numbers in this assay, from the lowest: compound 1; then compounds 3 and 2 (each within the scatter of the next).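

In this assay the exchange of methoxy for methylamino gives a 1.3-fold lower number from compound 2 to compound 3 (0.11 log units; within the scatter) and so stays inside the usual scatter, which means these two groups cannot be told apart at this position. The result also shows that the gain over ethylcarbamoyl is not confined to the methoxymethyl group, since (methylamino)methyl gives a 2.3-fold higher number from compound 1 to compound 3 (0.37 log units; beyond the scatter) and that step lies beyond the scatter. No available evidence accounts for these numbers. Still open, from the compounds shown here alone, is whether a carboxylic acid, a dimethylamino group or a longer chain at this position would shift the half-life further.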